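A few compounds are considered here, and "the series" means these few. Any claim that something is new, unique, unknown or untested is made for them only; others in the source may bear on it.

Compound 1 `CCCCCCCCCCCCCCC(NC(=O)OC(C)(C)C)C(=O)O` carries a long saturated chain, a carboxy group and a tert-butoxycarbonyl group on its amine nitrogen. In an ADME assay on cells (Splenocyte, Mus musculus, strain BALB/c) for cytotoxicity, read by MTT assay, tested at 10 ug/mL (a higher number here means a stronger effect of the compound at the concentration tested, a lower number a weaker effect), compound 1 gives 5.1%. Two relatives change only the carboxy group: compound 2 `CCCCCCCCCCCCCCC(CN(CC)CC)NC(=O)OC(C)(C)C` gives 7.8% and compound 3 `CCCCCCCCCCCCCCC(CNC(=O)CCCC(=O)O)NC(=O)OC(C)(C)C` gives 1.2%. The number for compound 1 falls between those two, yet every step among the three lies within the scatter: a number 2.7 percentage points higher from compound 1 to compound 2 (within the scatter), a number 3.9 percentage points lower from compound 1 to compound 3 (within the scatter) and a number 6.6 percentage points lower from compound 2 to compound 3 (within the scatter). Compound 4 `CCCCCCCCCCCCCCC(NCCCC)C(=O)O` keeps the carboxy group of compound 1 and differs elsewhere: butyl in place of tert-butoxycarbonyl on an amine nitrogen. Among the measured compounds shown here, no measured step touches the amine nitrogen, so none bears directly on this change; the steps seen so far, all at the carboxy group, stayed within the scatter. The expected step is therefore a number 0.1 percentage points lower from compound 1 to compound 4 (within the scatter), which means nothing beyond the scatter. Compound 4 is estimated at 5% in this assay, with a range from 0% to 15%.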

Compound 4, a percentage reported as activity, at one concentration (the size of the read-out at that concentration, not a potency): 5.1%
For compound 4 the middle estimate is 0.1 percentage points below the measured one; the measured number falls inside the stated range.
By their numbers in this assay, from the lowest: compounds 3, 1, 4 and 2 (each within the scatter of the next).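

With butyl in place of tert-butoxycarbonyl on an amine nitrogen, this assay shows no change at the digits printed from compound 1 to compound 4 (within the scatter), the first step read at this position rather than at the carboxy group. The change is not a small one on paper: a group holding oxygen and a double bond leaves, and a group of carbon alone enters, yet the step stays within the scatter. Nothing measured here offers an explanation for this result.

On these data alone, it remains open whether a free amine, a benzyl group or a longer chain on this nitrogen would also stay within the scatter. Every step read so far lies within the scatter, so the compounds shown do not tell which part of the core of compound 1, if any, matters for this read-out.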